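The source may report more compounds than this note shows. Statements on the series, on what has been measured and on what is new or still open speak of the compounds shown alone.

In an assay on isolated protein for inhibition of DNA topoisomerase 1 (Homo sapiens), with a stated time of 30 min, tested at 20 uM (on this read-out higher numbers stand for a stronger effect at the one concentration tested and lower numbers for a weaker effect), compound 2 `O=C(CN1CCN(c2cc3c(cc2F)c(=O)c(C(=O)O)cn3C2CC2)CC1)Nc1ccc(C(=O)/C=C/c2cccc(Cl)c2)cc1` gives 3.1%; this is the second highest of the three numbers shown, with compound 1 `O=C(CN1CCN(c2cc3c(cc2F)c(=O)c(C(=O)O)cn3C2CC2)CC1)Nc1ccc(C(=O)/C=C/c2ccccc2Cl)cc1` at 4.2% the nearest and compound 3 `O=C(CN1CCN(c2cc3c(cc2F)c(=O)c(C(=O)O)cn3C2CC2)CC1)Nc1ccc(C(=O)/C=C/c2ccc(Cl)cc2)cc1` at 0.4% the furthest, all three lying within the scatter of one another. The three differ only in where the chloro sits on the phenyl: a number 1.1 percentage points lower from compound 1 to compound 2 (within the scatter), a number 3.8 percentage points lower from compound 1 to compound 3 (within the scatter) and a number 2.7 percentage points lower from compound 2 to compound 3 (within the scatter), each within the scatter. Compound 4 `O=C(CN1CCN(c2cc3c(cc2F)c(=O)c(C(=O)O)cn3C2CC2)CC1)Nc1ccc(C(=O)/C=C/c2cccc([N+](=O)[O-])c2)cc1` brings a change of another kind: nitro in place of chloro on an aromatic carbon. Within the data shown here, no measured step exchanges chloro for any other group, so none of the three bears directly on it; what they show is only that shifting the chloro around the ring leaves this assay flat, and that none of the three climbs much above the bottom of the scale. For compound 4 the step expected from compound 2 is a number 0.9 percentage points higher from compound 2 to compound 4 (within the scatter), nothing beyond the scatter. Compound 4 is therefore estimated at 4%, between 0% and 14%.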

Compound 4, a percentage reported as inhibition, at one concentration (the size of the read-out at that concentration, not a potency): 11.1%
For compound 4 the middle estimate is 7.1 percentage points below the measured one; measured number inside the range.
By their numbers in this assay, from the lowest: compounds 3, 2, 1 and 4 (each within the scatter of the next, the first and the last beyond it).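

Exchanging the group itself, and not only moving the chloro, gives a number 8 percentage points higher from compound 2 to compound 4 (within the scatter) in this assay and a number 6.9 percentage points higher from compound 1 to compound 4 (within the scatter) as well, so at this place nitro cannot be told apart from either of those chloro compounds. Only a number 10.7 percentage points higher from compound 3 to compound 4 (beyond the scatter) clears the scatter, and that step changes both the group and its place on the ring, so it does not isolate the effect of nitro. No supporting measurement is available to account for this separation.

Open, on these data alone, is whether an amine, a carboxylic acid or a methoxy group in place of the nitro would give a number clearly apart from compound 2, and whether nitro elsewhere on the ring would match compound 4. As far as these compounds go, since the read-out comes from one concentration, the potency of compound 4 also remains open.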